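From methoxy to ethoxy: the step after compound 3

This account rests on a few compounds, and the source may have more. Where it says the series, first, only, none or still open, it means among the compounds named here.

Three compounds share one core and differ in a single group on an aromatic carbon. In a functional assay on HT-29 cells (Homo sapiens) for antiproliferative activity, read by MTT assay, with a stated time of 72 h (on this read-out higher numbers stand for weaker inhibition and lower numbers for stronger inhibition), compound 1 (`CNc1nc(-c2cc(OC)c(OC)c(OC)c2)c(-c2ccc(C)cc2)s1`), which carries methyl, gives 423 nM. Compound 2 (`CNc1nc(-c2cc(OC)c(OC)c(OC)c2)c(-c2ccc(C(F)(F)F)cc2)s1`), which carries trifluoromethyl, gives 1240 nM. Compound 3 (`CNc1nc(-c2cc(OC)c(OC)c(OC)c2)c(-c2ccc(OC)cc2)s1`), which carries methoxy, gives 6.3 nM, the lowest number of the three and the strongest inhibition.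

Compound 4 (`CCOc1ccc(-c2sc(NC)nc2-c2cc(OC)c(OC)c(OC)c2)cc1`) turns the 4-methoxyphenyl of compound 3 into 4-ethoxyphenyl: methyl in place of hydrogen on a saturated chain carbon bound to an oxygen on an aromatic ring.

Among the measured compounds shown here, two measured steps bear on this change, both large: a 67-fold lower number from compound 1 to compound 3 (1.83 log units; beyond the scatter) and a 200-fold lower number from compound 2 to compound 3 (2.29 log units; beyond the scatter). The third, a 2.9-fold higher number from compound 1 to compound 2 (0.47 log units; beyond the scatter), is modest. Together they show that the numbers can move far when this group is changed, but none of them goes from methoxy to ethoxy, so the series holds no direct precedent. The new change is small and keeps the oxygen, so a step as large as those two is not the likeliest outcome, though some loss from so low a starting value seems probable. In this assay a modest step toward weaker inhibition is expected, namely a 4.0-fold higher number from compound 3 to compound 4 (0.60 log units; beyond the scatter). For compound 4 the estimate is 25 nM, with an expected range from 6 nM to 120 nM.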

Compound 4, half-maximal inhibitory concentration: 3.2 nM
Compound 4: middle estimate off by 7.8-fold (0.89 log units), on the high side, outside the stated range (below it).
By their numbers in this assay, from the lowest: compounds 4 and 3 (each within the scatter of the next); then compound 1; then compound 2.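

In this assay, adding methyl on a saturated chain carbon bound to an oxygen on an aromatic ring gives a 2.0-fold lower number from compound 3 to compound 4 (0.29 log units; within the scatter), so methoxy and ethoxy cannot be told apart at this position. Among the compounds shown here, the earlier compounds had only one group with an oxygen on the aromatic carbon, and compound 4 now supplies a second: ethoxy stands as far from the other two groups as methoxy does, with a 130-fold lower number from compound 1 to compound 4 (2.12 log units; beyond the scatter) and a 390-fold lower number from compound 2 to compound 4 (2.59 log units; beyond the scatter), both large. Among these four compounds, the two carrying an oxygen on that aromatic carbon, compound 3 and compound 4, thus sit well apart from the two carrying methyl and trifluoromethyl, and no compound shown goes against this. Nothing given here explains why the numbers fall this way.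

The compounds shown leave open how far the chain on the oxygen can grow before the numbers move, since a longer chain such as propoxy or butoxy, or a branched one such as isopropoxy, lies outside this set. They also leave open whether the oxygen itself matters, which a hydroxyl or an amine at the same place would begin to address.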